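This account rests on a few compounds, and the source may have more. Where it says the series, first, only, none or still open, it means among the compounds named here.

Measured in an ADME assay on HOS cells (Homo sapiens) for cytotoxicity, read by luminescence and ATP content, with a stated time of 48 h; on this read-out higher numbers stand for lower toxicity in this test and lower numbers for higher toxicity in this test:
- Compound 1 `CC(=O)OCCCc1cnc2c(c1)c(N)c(C(=O)NCc1ccc(F)cc1F)c(=O)n2O`: > 250000 nM
- Compound 2 `Nc1c(C(=O)NCc2ccc(F)cc2F)c(=O)n(O)c2ncc(CCCCc3ccccc3)cc12`: 13000 nM

The entry for compound 1, > 250000 nM, is a limit of the assay and not a number. Among the measured compounds shown here, that leaves compound 2, at 13000 nM, with the only exact value so far, so there is no series of numbers to rank it against.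

The next compound, compound 3 `Nc1c(C(=O)NCc2ccc(F)cc2F)c(=O)n(O)c2ncc(CCc3ccccc3)cc12`, keeps the shared core and the phenyl end of the chain but has a shorter chain: phenyl in place of phenethyl on a saturated chain carbon, two bonds along the chain from an aromatic carbon. Cut one bond further out, this reads 4-phenylbutyl to phenethyl.

For the measured compounds named here, only one measured step bears on this change, and it is large and beyond the scatter: an at least 19-fold lower number from compound 1 to compound 2 (1.28 log units; beyond the scatter). It swaps the chain end, whereas compound 3 keeps its phenyl, so only a small part of that step is expected to return. In this assay, the expected result is a modest move towards a higher number, that is, lower toxicity in this test. The estimated step is a 2.3-fold higher number from compound 2 to compound 3 (0.36 log units; beyond the scatter). The estimate for compound 3 is 30000 nM, with an expected range from 11000 nM to 90000 nM.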

Compound 3, half-maximal cytotoxic concentration: 18000 nM
Compound 3: the middle estimate sits 1.7-fold (0.22 log units) above what was measured; measured number inside the range.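

With the phenyl end kept, the 4-phenylbutyl chain and the phenethyl chain cannot be told apart in this assay, with a 1.4-fold higher number from compound 2 to compound 3 (0.14 log units; within the scatter). The large gap to the compound with the acetoxy end appears again with the shorter chain, at an at least 13-fold lower number from compound 1 to compound 3 (1.14 log units; beyond the scatter), so among these compounds the gap goes with what ends the chain and not with the chain length alone. The entry for compound 1 is a limit and not a number, and this holds for the step that starts from it as well: the limit of > 250000 nM in this assay, at which 1 of the 3 values shown sits.

The compounds shown leave open whether a phenyl end is what brings the number down at this position, or whether another end group, such as an amine or a carboxylic acid, would sit with the phenyl compounds or with the acetoxy compound. On these data alone, a longer chain than 4-phenylbutyl and a chain with only one or two carbons before the phenyl ring also remain open, so how far the two chain lengths seen here can be extended in either direction is still unknown.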